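Removing One Hydroxy Group from a Trihydroxy Imine

The source may report more compounds than this note shows. Statements on the series, on what has been measured and on what is new or still open speak of the compounds shown alone.

Measured so far in an assay on isolated protein for inhibition of Amine oxidase [flavin-containing] B (Homo sapiens), read by fluorescence and Amplex Red, with stated times of 15 min and 20 min; on this read-out lower numbers stand for stronger inhibition and higher numbers for weaker inhibition:
compound 1 `Oc1cc(O)c(/C=N/c2ccc(OCc3ccccc3)cc2)c(O)c1` gives 10100 nM
compound 2 `Oc1ccc2ccccc2c1/C=N/c1ccc(OCc2ccccc2)cc1` gives 19200 nM
compound 3 `COc1cccc(/C=N/c2ccc(OCc3ccccc3)cc2)c1O` gives 6500 nM

All three compounds share a core and differ only in the ring that carries the hydroxy groups. The number for compound 1 sits within the usual scatter of both compound 3 and compound 2, so the three cannot be told apart on these data.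

Compound 4 `Oc1ccc(/C=N/c2ccc(OCc3ccccc3)cc2)c(O)c1` differs from compound 1 by a single change: hydrogen in place of hydroxy on an aromatic carbon. Among the compounds with values here, no step between two measured compounds shows what such a change does here, so a step of no more than the scatter is expected in either direction. For compound 4 in this assay a value of 8000 nM is estimated, in the range 3000 nM to 25000 nM, which corresponds to an expected step of a 1.3-fold lower number from compound 1 to compound 4 (0.10 log units; within the scatter).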

Compound 4, half-maximal inhibitory concentration: 6780 nM
Compound 4: middle estimate off by 1.2-fold (0.07 log units), on the high side; measured number inside the range.
By their numbers in this assay, from the lowest: compounds 3, 4, 1 and 2 (each within the scatter of the next, the first and the last beyond it).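

Putting hydrogen in place of hydroxy on this aromatic carbon, ortho to a large group, gives a 1.5-fold lower number from compound 1 to compound 4 (0.17 log units; within the scatter) in this assay. Within the data shown here, this is the first direct view of a single change, and it shows that the number stays within the scatter when this hydroxy group is lost. No measurement here explains this result or shows what this hydroxy group does. On these data alone, it remains open whether an amine or a carboxylic acid on this carbon would shift the number beyond the scatter. As far as these compounds go, the effect of removing either of the two remaining hydroxy groups is also open.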